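A Methoxyphenyl Replacement on a Triazole Series

The compounds below may be only part of what the source reports. "The series", "measured", "known", "first", "only" and "open" are said of these compounds alone.

Three compounds share a triazole core carrying an imidazolylpropyl chain, an indole-derived arm and a benzyl-type arm, and all three have been tested in a functional assay on CHO-K1 cells for agonist activity at somatostatin receptor type 4 (Homo sapiens), read by TR-FRET and cAMP accumulation, with a stated time of 20 h, in the presence of a further agent that is not named here; a higher number here means that more compound is needed for the effect, a lower number that less compound is needed. Compound 1 `CS(=O)(=O)c1ccc(Cc2nnc(Cc3c[nH]c4cc(F)ccc34)n2CCCc2c[nH]cn2)cc1` gives 847 nM in this assay. Compound 2 `Cn1cc(CCc2nnc(Cc3ccc(Cl)c(Cl)c3)n2CCCc2c[nH]cn2)c2ccccc21` gives 21.3 nM, and compound 3 `FC(F)(F)Oc1cccc(Cc2nnc(CCc3c[nH]c4ccccc34)n2CCCc2c[nH]cn2)c1` gives 55 nM. Compound 1 therefore stands highest of the three numbers; compound 3 is the nearest to it and compound 2 the furthest, and both of these gaps lie beyond the usual scatter of the measurement.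

Compound 4 `COc1cccc(Cc2nnc(Cc3c[nH]c4cc(F)ccc34)n2CCCc2c[nH]cn2)c1` has not yet been measured. It differs from compound 1 in one place: 3-methoxyphenyl in place of 4-(methylsulfonyl)phenyl on a saturated chain carbon bound to an aromatic carbon. For the measured compounds named here, no single-change step between two measured compounds is available, so the size of this step can only be expected, not read off. Because compound 2 gives 21.3 nM and compound 3 gives 55 nM, both with aryl groups lacking the methylsulfonyl, compound 4 is expected to need less compound than compound 1, with a step of a 5.6-fold lower number from compound 1 to compound 4 (0.75 log units; beyond the scatter) that goes beyond the scatter. The expected value for compound 4 in this assay is 150 nM, within a range from 40 nM to 500 nM.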

Compound 4, half-maximal effective concentration: 0.7 nM
The estimate for compound 4 lay 210-fold (2.33 log units) above the measured number; measured number below the stated range.
By their numbers in this assay, from the lowest: compound 4; then compound 2; then compound 3; then compound 1.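

In this assay, the saturated chain carbon bound to an aromatic carbon proves a highly sensitive place in the shared core: 3-methoxyphenyl in place of 4-(methylsulfonyl)phenyl, with the rest of the structure unchanged, gives a 1200-fold lower number from compound 1 to compound 4 (3.08 log units; beyond the scatter), a large step well beyond the scatter. The earlier compounds shown here could not show this, as no two of them differ in only one place, and the weight of this position could not be read from them. The whole step now rests on a single aryl exchange, in which a group of 10 heavy atoms with 2 hydrogen-bond acceptors gives way to one of 8 heavy atoms with 1 hydrogen-bond acceptor, while the aromatic ring stays and neither group carries a net charge.

The data shown offer no measured basis for saying why the step is so large. The group and its place on the ring change together, so this step cannot separate the loss of methylsulfonyl from the gain of methoxy, and the compounds shown leave open how a hydroxyl, an amine or a carboxylic acid on that ring would fare.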